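The source may hold more compounds than are shown below. What is called first, only, known or untested is meant among the compounds shown, and "the series" means these compounds.

Measured compounds:
compound 1 `COc1cc2c(Nc3ccc4sc(C(=O)Nc5c(C)cccc5Cl)cc4c3)ncnc2cc1OCCCN1CCCCC1C` with 80.3%
compound 2 `COc1cc2c(Nc3ccc4sc(C(=O)Nc5c(C)cccc5Cl)cc4c3)ncnc2cc1OCCCN1CCCCC1` with 75.7%
compound 3 `Cc1nc(Nc2ccc3sc(C(=O)Nc4c(C)cccc4Cl)cc3c2)cc(N2CCC(C)CC2)n1` with 24.6%

All three were tested in a functional assay on U-937 cells (Homo sapiens) for inhibition, read by MTT assay and WST assay, with a stated time of 72 h, tested at 10 uM; on this read-out higher numbers stand for more inhibition of growth at the one concentration tested and lower numbers for less inhibition of growth. Compound 3 stands lowest of the three: compound 2 lies above it by a wide margin and compound 1 by a still wider one, both beyond the usual scatter. Compound 4 `CCN1CCN(c2cc(Nc3ccc4sc(C(=O)Nc5c(C)cccc5Cl)cc4c3)nc(C)n2)CC1` has not yet been measured. It differs from compound 3 in one place: 4-ethylpiperazin-1-yl in place of 4-methylpiperidin-1-yl on an aromatic carbon. Going by the values given here, no measured step matches this change. Among the compounds with values here, the only recorded step, a number 4.6 percentage points lower from compound 1 to compound 2 (within the scatter), concerns a different core and a different kind of change, so it offers little guidance here. Within the data shown here, with no close precedent, the expectation for compound 4 is a modest rise, a number 7.4 percentage points higher from compound 3 to compound 4 (within the scatter), carrying wide uncertainty. Compound 4 is therefore estimated at 32%, ranging from 10% to 60%.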

Compound 4, percent growth inhibition at one concentration: 46.5%
Compound 4: the middle estimate sits 14.5 percentage points below what was measured, within the range that was stated.
By their numbers in this assay, from the lowest: compound 3; then compound 4; then compounds 2 and 1 (each within the scatter of the next).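

In this assay, putting 4-ethylpiperazin-1-yl in place of 4-methylpiperidin-1-yl on an aromatic carbon next to the ring nitrogen gives a number 21.9 percentage points higher from compound 3 to compound 4 (beyond the scatter). Going by these compounds alone, the only earlier step, a number 4.6 percentage points lower from compound 1 to compound 2 (within the scatter), concerned a saturated ring carbon on a different core; this one shows that the group on this aromatic carbon can shift growth inhibition. Nothing measured here gives a reason for the rise. The second ring nitrogen and the ethyl group enter together, leaving their separate shares unknown. A 4-methylpiperazin-1-yl group or a morpholine at this position could help to separate them.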